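A few compounds are considered here, and "the series" means these few. Any claim that something is new, unique, unknown or untested is made for them only; others in the source may bear on it.

Measured compounds:
compound 1, `COc1cc2c(Nc3ccc(C#N)cc3)ncnc2cc1OCCCN(C)C`: 34900 nM
compound 2, `CCOC(=O)C1CCN(CCCOc2cc3ncnc(Nc4ccc(C#N)cc4)c3cc2OC)CC1`: 47200 nM
compound 3, `COc1cc2c(Nc3ccc(C#N)cc3)ncnc2cc1OCCCN1CCN(C)CC1`: 13000 nM

The account follows the step from compound 1 to compound 4, `CCN1CCN(CCCOc2cc3ncnc(Nc4ccc(C#N)cc4)c3cc2OC)CC1`. In a functional assay on SH-SY5Y cells (Homo sapiens) for antiproliferative activity, read by MTT assay, with a stated time of 72 h (a higher number here means a weaker inhibitor, a lower number a stronger inhibitor), compound 1 stands second highest of the three numbers: the nearest is compound 2, with a 1.4-fold higher number from compound 1 to compound 2 (0.13 log units; within the scatter), and the furthest is compound 3, with a 2.7-fold lower number from compound 1 to compound 3 (0.43 log units; beyond the scatter). The change to compound 4 is 4-ethylpiperazin-1-yl in place of dimethylamino on a saturated chain carbon, three bonds along the chain from an oxygen on an aromatic ring. For the measured compounds named here, the step that bears most on it is the one to compound 3, where 4-methylpiperazin-1-yl entered at the same place and gave a 2.7-fold lower number from compound 1 to compound 3 (0.43 log units; beyond the scatter); the step from compound 2 to compound 3, with a 3.6-fold lower number from compound 2 to compound 3 (0.56 log units; beyond the scatter), points the same way. Compound 4 differs from compound 3 only in the ethyl in place of the methyl on the piperazine, so a modest lower number in this assay is expected, close to that of compound 3, with a 2.5-fold lower number from compound 1 to compound 4 (0.40 log units; beyond the scatter). Compound 4 is therefore estimated at 14000 nM, in the range 6000 nM to 33000 nM.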

Compound 4, half-maximal inhibitory concentration: 5440 nM
The estimate for compound 4 lay 2.6-fold (0.41 log units) above the measured number; the whole stated range lies above it.
By their numbers in this assay, from the lowest: compound 4; then compound 3; then compounds 1 and 2 (each within the scatter of the next).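

In this assay, 4-ethylpiperazin-1-yl in place of dimethylamino at this place on the chain gave a 6.4-fold lower number from compound 1 to compound 4 (0.81 log units; beyond the scatter), and in place of 4-(ethoxycarbonyl)piperidin-1-yl it gave an 8.7-fold lower number from compound 2 to compound 4 (0.94 log units; beyond the scatter), the largest step among the compounds shown. For the compounds shown here, what the earlier compounds did not show is that the piperazine's own substituent also counts here: the extra methyl that turns the methyl of compound 3 into the ethyl of compound 4 gave a 2.4-fold lower number from compound 3 to compound 4 (0.38 log units; beyond the scatter), so these two compounds cannot be treated as interchangeable. Nothing available explains this difference.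

From the compounds shown here alone, with only methyl and ethyl on the piperazine, it remains open whether a propyl, an isopropyl or a benzyl group there would continue the step or reverse it. A shorter or longer chain carrying the 4-ethylpiperazin-1-yl group also remains untested among these compounds.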